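Halogen in Place of Hydrogen on the Benzyl Ring

The source may hold more compounds than are shown below. What is called first, only, known or untested is meant among the compounds shown, and "the series" means these compounds.

Three compounds carry numbers in a functional assay on NCI-H460 cells (Homo sapiens) for cytotoxicity, read by sulforhodamine B assay, with a stated time of 3 days; on this read-out higher numbers stand for weaker inhibition and lower numbers for stronger inhibition. Compound 1 `O=CC1C(=O)N(Cc2ccc(Cl)cc2)c2cc(Cl)ccc21` gives 18200 nM, compound 2 `OCc1cn(Cc2ccccc2)c2ccccc12` gives 112 nM, and compound 3 `OCc1cn(Cc2cccc(F)c2)c2ccccc12` gives 40 nM. Compound 2 therefore stands second highest of the three: compound 3 is its nearest neighbour, while compound 1 lies far above it, a gap well beyond the scatter. Within the data shown here, the only step between compounds that differ in one place is a 2.8-fold lower number from compound 2 to compound 3 (0.45 log units; beyond the scatter), a modest move that nonetheless lies beyond the scatter.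

Compound 4 `OCc1cn(Cc2ccccc2Cl)c2ccccc12` differs from compound 2 by chloro in place of hydrogen on an aromatic carbon. The step from compound 2 to compound 3 is the one that bears on this change, since there too a halogen entered an aromatic carbon of the same six-membered aromatic ring of carbon only. Chloro is not fluoro, however, and in compound 4 the halogen sits ortho to a large group, a place no measured compound probes. A lowering of roughly the size seen from compound 2 to compound 3 is therefore expected, though one no larger than the scatter would not surprise. Compound 4 is thus estimated at 70 nM, within 25 nM to 250 nM, which is expected to correspond to a 1.6-fold lower number from compound 2 to compound 4 (0.20 log units; within the scatter).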

Compound 4, half-maximal inhibitory concentration: 100 nM
Beside the measured number, compound 4's estimate is 1.4-fold (0.15 log units) below it; measured number inside the range.
By their numbers in this assay, from the lowest: compound 3; then compounds 4 and 2 (each within the scatter of the next); then compound 1.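

In this assay, chloro on an aromatic carbon of the six-membered aromatic ring of carbon only, ortho to a large group, gives a 1.1-fold lower number from compound 2 to compound 4 (0.05 log units; within the scatter), so at this position a chlorine atom brings no change that can be told from the scatter. A halogen on this ring therefore does not by itself go with a lower number: a 2.8-fold lower number from compound 2 to compound 3 (0.45 log units; beyond the scatter) lies beyond the scatter and the new step does not, yet compound 3 and compound 4 differ in both the halogen and its place, so these two factors cannot be separated. Nothing measured here offers an explanation for how the chloro change came out.

The compounds shown leave open whether chloro on the carbon that carries fluoro in compound 3, or fluoro ortho to a large group, would give a step beyond the scatter, which would show whether the halogen or its place matters more. They also leave open what a larger group at the same place, such as methoxy, trifluoromethyl or an amine, would do to the number in this assay.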